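The source may report more compounds than this note shows. Statements on the series, on what has been measured and on what is new or still open speak of the compounds shown alone.

Working notes on the series. The shared core carries an aryl ketone on a saturated chain carbon; compound 1 `COc1cc(-c2nnc(SCC(=O)c3ccc(F)cc3)n2N)cc(OC)c1OC`, compound 2 `COc1cc(-c2nnc(SCC(=O)c3ccc(F)c(F)c3)n2N)cc(OC)c1OC` and compound 3 `COc1cc(-c2nnc(SCC(=O)c3ccccc3F)n2N)cc(OC)c1OC` differ only in that aryl group. In a functional assay on PC-3 cells (Homo sapiens) for antiproliferative activity, read by MTT assay, with a stated time of 48 h (a higher number here means a weaker inhibitor, a lower number a stronger inhibitor), compound 1 gives only a limit, > 100000 nM. Compound 2 likewise gives only a limit in this assay, > 100000 nM. Among the measured compounds shown here, compound 3 is the one compound with a number in this assay, at 43100 nM, the other two values sitting at the limit of > 100000 nM in this assay, at which 2 of the 3 values shown sit. The measured steps read an at least 2.3-fold lower number from compound 1 to compound 3 (0.36 log units; beyond the scatter) and an at least 2.3-fold lower number from compound 2 to compound 3 (0.36 log units; beyond the scatter).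

From the compounds shown here alone, compound 4 `COc1ccc(C(=O)CSc2nnc(-c3cc(OC)c(OC)c(OC)c3)n2N)cc1` is untested; its change from compound 3 is 4-methoxyphenyl in place of 2-fluorophenyl on a carbonyl carbon. Both measured steps bear on this: going from 4-fluorophenyl or 3,4-difluorophenyl to 2-fluorophenyl lowered the number in this assay at least modestly, and compound 4 returns to a ring substituted in the manner of compound 1 and compound 2, with methoxy rather than fluoro. For compound 4 a step back toward weaker inhibition is expected, a 2.3-fold higher number from compound 3 to compound 4 (0.37 log units; beyond the scatter). Compound 4 is therefore estimated at 100000 nM, within 40000 nM to 300000 nM, with a fair chance that only a limit is reported.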

Compound 4, half-maximal inhibitory concentration: 97900 nM
Compound 4: middle estimate off by 1.0-fold (0.01 log units), on the high side, and the stated range covers the measured number.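

In this assay, 4-methoxyphenyl on the carbonyl carbon does not keep what 2-fluorophenyl gave, with a 2.3-fold higher number from compound 3 to compound 4 (0.36 log units; beyond the scatter), so compound 3 stays the strongest of the four, its steps to all three others being beyond the scatter. Methoxy in place of fluoro shows no readable gain, with an at least 1.0-fold lower number from compound 1 to compound 4 (0.00 log units; that floor lies within the scatter), and the change from 3,4-difluorophenyl reads the same, with an at least 1.0-fold lower number from compound 2 to compound 4 (0.00 log units; that floor lies within the scatter). Both of these steps are only floors, because the values they start from are limits: the limit of > 100000 nM in this assay, at which 2 of the 4 values shown sit.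

From the compounds shown here alone, whether the lower number of compound 3 belongs to fluoro itself or to any group placed as in 2-fluorophenyl remains open. A 2-methoxyphenyl or 2-chlorophenyl group, or a plain phenyl, on the carbonyl carbon would bear on that question.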